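Methoxy for phenyl on a weak growth inhibitor

This account rests on a few compounds, and the source may have more. Where it says the series, first, only, none or still open, it means among the compounds named here.

Two members of this series have been measured. Compound 1 `CC(=O)c1cccc(Nc2ccnc(SCC(=O)c3ccc(-c4ccccc4)cc3)n2)c1` was tested in a functional assay on HCT-116 cells (Homo sapiens) for inhibition, read by sulforhodamine B assay, with a stated time of 48 h, tested at 10 uM (on this read-out higher numbers stand for more inhibition of growth at the one concentration tested and lower numbers for less inhibition of growth), and gives 14%. Compound 2 `CCOC(=O)c1ccc(Nc2ccnc(SCC(=O)c3ccc([N+](=O)[O-])cc3)n2)cc1` gives 26% in the same setting, and in this assay compound 1 therefore stands as the lower of the two numbers, with compound 2 the nearest comparison, lying higher by a gap that exceeds the usual scatter. Among the compounds with values here, no pair of measured compounds differs in just one place, so no single structural step has yet been tied to a change in the read-out.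

Compound 3 `COc1ccc(C(=O)CSc2nccc(Nc3cccc(C(C)=O)c3)n2)cc1` has not been measured. It differs from compound 1 as follows: methoxy in place of phenyl on an aromatic carbon. The methoxy group sits on an aromatic carbon of a six-membered aromatic ring of carbon only, para to a large group. Because compound 1 gives 14% and compound 2 gives 26%, both at the low end of the scale, the step of a number 1 percentage points higher from compound 1 to compound 3 (within the scatter) is expected to be small, likely within the scatter in either direction. Compound 3 is accordingly estimated at 15%, with a range from 3% to 30%.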

Compound 3, percent growth inhibition at one concentration: 23%
Compound 3: the middle estimate sits 8 percentage points below what was measured; the measured number falls inside the stated range.
By their numbers in this assay, from the lowest: compounds 1, 3 and 2 (each within the scatter of the next, the first and the last beyond it).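

Within the data shown here, this is the first step that can be read in one place: on an aromatic carbon of a six-membered aromatic ring of carbon only, para to a large group, methoxy in place of phenyl gives a number 9 percentage points higher from compound 1 to compound 3 (within the scatter) in this assay. The position therefore accepts an exchange of phenyl, with its 6 heavy atoms and its ring, for methoxy, with 2 heavy atoms, no ring and 1 hydrogen-bond acceptor, while compound 1 and compound 3 remain indistinguishable on this read-out. No independent measurement accompanies this result, so it offers no explanation for how the two groups compare.

As far as these compounds go, with only phenyl and methoxy compared at this position, it remains open whether an amine, a carboxylic acid, a chlorine atom or a longer chain such as butoxy would give a number beyond the scatter from that of compound 1. From the compounds shown here alone, compound 2 differs from compound 1 and compound 3 in more than one place, so what sets its number apart from that of compound 1 also remains open.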